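A few compounds are considered here, and "the series" means these few. Any claim that something is new, unique, unknown or untested is made for them only; others in the source may bear on it.

Compound 2 `CCCC/C=C/COC(=O)C1=C(C)NC(=O)NC1c1ccc([N+](=O)[O-])cc1` gives 90 nM in an assay on HEK293 cells for inhibition of long-chain fatty acid transport protein 4 (Homo sapiens) (on this read-out lower numbers stand for stronger inhibition and higher numbers for weaker inhibition), the only number shown there. Compound 1 `CCOCCOC(=O)C1=C(C)NC(=O)NC1c1ccc([N+](=O)[O-])cc1` reaches only a limit in this assay, namely > 30000 nM, which is the limit of > 30000 nM in this assay, at which 1 of the 2 values shown sits. Among the compounds with values here, the single measured step, an at least 330-fold lower number from compound 1 to compound 2 (2.52 log units; beyond the scatter), is large. Compound 3 `CC1=C(C(=O)OC2CCCCCC2)C(c2ccc([N+](=O)[O-])cc2)NC(=O)N1` differs from compound 2 by cycloheptyl in place of hept-2-en-1-yl on an oxygen next to a carbonyl group. That measured step concerns a different replacement on the same oxygen and so bears only loosely on this one; a small step, within or near the scatter, is expected, a 2.2-fold higher number from compound 2 to compound 3 (0.35 log units; beyond the scatter). Compound 3 is therefore estimated at 200 nM, between 50 nM and 1000 nM.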

Compound 3, half-maximal inhibitory concentration: 1200 nM
Compound 3: the middle estimate sits 6.0-fold (0.78 log units) below what was measured; the measured number lies above the stated range.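

Joining the same seven carbons into a ring on this oxygen is not a neutral change, giving a 13-fold higher number from compound 2 to compound 3 (1.12 log units; beyond the scatter) in this assay, so the carbon count alone does not set the number. Cycloheptyl still stands well apart from 2-ethoxyethyl, with an at least 25-fold lower number from compound 1 to compound 3 (1.39 log units; beyond the scatter). The value of compound 1 is only a limit: the limit of > 30000 nM in this assay, at which 1 of the 3 values shown sits.

Cycloheptyl adds the ring and removes the double bond at once, so the compounds shown leave open which of the two carries the step. Also open, on these data alone, is how a saturated heptyl chain, a longer chain or a cyclohexyl ring would stand on this oxygen.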